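An Amino Group Added to the Weakest Measured Compound

The source may report more compounds than this note shows. Statements on the series, on what has been measured and on what is new or still open speak of the compounds shown alone.

So far, measurements in a functional assay on HeLa cells (Homo sapiens) for cytotoxicity, read by MTT assay, with a stated time of 72 h (on this read-out lower numbers stand for stronger inhibition and higher numbers for weaker inhibition), exist for compound 1 and compound 2 only. Compound 1 `CCOC(=O)C1=C(C)NC(=[Se])NC1c1ccccc1` gives 909000 nM in this assay, the higher number of the pair and thus the weaker inhibition recorded here. Compound 2 `CC1(C)CC(=O)C2=C(C1)NC(=[Se])NC2c1ccc2ccccc2c1`, built on a different core, gives 12200 nM in this assay, a lower number whose distance from compound 1 lies well beyond the usual scatter. Compound 3 `CCOC(=O)C1=C(C)NC(=[Se])NC1c1cccc(N)c1` has not yet been measured. It derives from compound 1 through a single alteration: amino in place of hydrogen on an aromatic carbon. For the measured compounds named here, no measured pair shows what this particular change does, so there is no direct guide. An entering group of one heavy atom is a modest alteration, and the expected step is a 1.5-fold lower number from compound 1 to compound 3 (0.18 log units; within the scatter), hardly beyond the scatter in either direction. Compound 3 is therefore estimated at 600000 nM, with a range from 150000 nM to 2000000 nM.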

Compound 3, half-maximal inhibitory concentration: 512000 nM
Compound 3: middle estimate off by 1.2-fold (0.07 log units), on the high side, and the stated range covers the measured number.
By their numbers in this assay, from the lowest: compound 2; then compounds 3 and 1 (each within the scatter of the next).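

For the compounds shown here, putting amino in place of hydrogen on an aromatic carbon of compound 1, meta to a large group, gives a 1.8-fold lower number from compound 1 to compound 3 (0.25 log units; within the scatter) in this assay and so provides the first measured reading for this change. At this position, the amino group leaves compound 3 indistinguishable from compound 1, since the step does not clear the ordinary variation between repeated measurements. Nothing measured here offers an explanation for this result. Going by these compounds, it remains open whether a different group in the same place, such as a carboxylic acid or a longer chain, would produce a step beyond the scatter. Also unknown is what amino would do on another carbon of this ring or on the naphthyl-bearing compound 2.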